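A few compounds are considered here, and "the series" means these few. Any claim that something is new, unique, unknown or untested is made for them only; others in the source may bear on it.

Compound 1 `Cc1nn(-c2ncnc3nc[nH]c23)c2c1C(OCC(=O)c1ccc(F)cc1)CC(=O)N2`: in a functional assay on HEK293 cells for agonist activity at G-protein coupled receptor 39 (Homo sapiens), read by scintillation proximity assay and inositol phosphate accumulation, with a stated time of 75 min (on this read-out higher numbers stand for an effect only at larger amounts of compound and lower numbers for an effect already at smaller amounts), compound 1 gives 973 nM.
Compound 2 `Cc1nn(-c2ncnc3nc[nH]c23)c2c1C(OCc1cc(F)cc3c1OCOC3)CC(=O)N2`: in this assay compound 2 gives 30 nM.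
Compound 3 `Cc1nn(-c2ncnc3nc[nH]c23)c2c1C(OCc1ccc(C(C)C)cc1)CC(=O)N2`: in this assay compound 3 gives 1690 nM.

Compound 2 stands lowest of the three numbers, and both of its neighbours lie beyond the scatter: a 32-fold lower number from compound 1 to compound 2 (1.51 log units; beyond the scatter), and a 56-fold higher number from compound 2 to compound 3 (1.75 log units; beyond the scatter). Compound 4 `Cc1cc(C)n(CCOC2CC(=O)Nc3c2c(C)nn3-c2ncnc3nc[nH]c23)n1` differs from compound 2 in one place: a group of 8 heavy atoms (6 carbon, 2 nitrogen; one five-membered aromatic ring with 2 hetero atoms) in place of a group of 11 heavy atoms (8 carbon, 2 oxygen, 1 fluorine; one six-membered non-aromatic ring with 2 hetero atoms, one six-membered aromatic ring of carbon only), on a saturated chain carbon bound to an oxygen on a saturated carbon. The two measured steps that change this same group, a 32-fold lower number from compound 1 to compound 2 (1.51 log units; beyond the scatter) and a 56-fold higher number from compound 2 to compound 3 (1.75 log units; beyond the scatter), show that leaving the group carried by compound 2 has each time cost a large amount of activity. Since compound 4 also gives up that group, a large step to a higher number in this assay is expected: a 27-fold higher number from compound 2 to compound 4 (1.43 log units; beyond the scatter). Compound 4 is therefore estimated at 800 nM, within a range from 150 nM to 4000 nM.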

Compound 4, half-maximal effective concentration: 2000 nM
Compound 4: the middle estimate sits 2.5-fold (0.40 log units) below what was measured; the measured number falls inside the stated range.
By their numbers in this assay, from the lowest: compound 2; then compounds 1, 3 and 4 (each within the scatter of the next, the first and the last beyond it).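

In this assay, a third departure from the group of compound 2 again costs a large amount of activity (a 67-fold higher number from compound 2 to compound 4 (1.82 log units; beyond the scatter)), this time with (3,5-dimethyl-1H-pyrazol-1-yl)methyl entering. That group gives no clear separation from 4-isopropylphenyl (a 1.2-fold higher number from compound 3 to compound 4 (0.07 log units; within the scatter)) and stands only modestly apart from (4-fluorophenyl)carbonyl (a 2.1-fold higher number from compound 1 to compound 4 (0.31 log units; beyond the scatter)), so three differently built groups all fall far short of compound 2. No measurement shown explains this gap.

From the compounds shown here alone, whether the fluorine or the non-aromatic ring of compound 2 matters more stays open. So does whether an amine or a carboxylic acid at this place could approach compound 2.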